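The compounds below may be only part of what the source reports. "The series", "measured", "known", "first", "only" and "open" are said of these compounds alone.

Three related compounds have been tested in a functional assay on IGROV-1 cells (Homo sapiens) for cytotoxicity, read by sulforhodamine B assay, with a stated time of 48 h; on this read-out higher numbers stand for weaker inhibition of growth and lower numbers for stronger inhibition of growth. Compound 1 `ClCc1ccc(Cn2cnc3nc(Cl)nc(Cl)c32)cc1` gives 1410 nM. Compound 3 `ClCc1ccccc1Cn1cnc2nc(Cl)nc(Cl)c21` gives 2880 nM, and compound 2 `ClCc1ccccc1Cn1cnc2ncnc(Cl)c21` gives 4260 nM. Among the three, compound 1 shows the strongest inhibition of growth, since both other numbers lie beyond the usual scatter of the measurement. Compound 3 and compound 2 differ in a single place: hydrogen in place of chloro on an aromatic carbon This change gave a 1.5-fold higher number from compound 3 to compound 2 (0.17 log units; within the scatter). Compound 1 and compound 3 are built from the same atoms joined differently; the difference between the two cores is not broken down here.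

Compound 4 `ClCc1ccc(Cn2cnc3ncnc(Cl)c32)cc1` has not yet been measured. It differs from compound 1 by the same change, at a place described in the same words: hydrogen in place of chloro on an aromatic carbon Because the same change gave a 1.5-fold higher number from compound 3 to compound 2 (0.17 log units; within the scatter), the expected step is a 1.5-fold higher number from compound 1 to compound 4 (0.17 log units; within the scatter). Compound 4 is therefore estimated at 2100 nM in this assay, most likely falling between 1100 nM and 4200 nM.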

Compound 4, concentration for 50% growth inhibition: 7580 nM
Compound 4: middle estimate off by 3.6-fold (0.56 log units), on the low side, and the stated range ends below it.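

In this assay, putting hydrogen in place of the chloro group between two ring nitrogen atoms gave a 5.4-fold higher number from compound 1 to compound 4 (0.73 log units; beyond the scatter). A change described in the same words therefore did not carry the same size of step from one core to the other, so a step measured on one core was a poor guide to the other here: the same change on two cores in this assay, a 1.5-fold higher number (0.17 log units; within the scatter) from compound 3 to compound 2 and a 5.4-fold higher number (0.73 log units; beyond the scatter) from compound 1 to compound 4, 3.6-fold (0.56 log units) apart, beyond the scatter of two such steps. Within the data shown here, only the step on the core of compound 1 lies beyond the scatter, but two pairs cannot give a typical size for this change across the series, and they do not show why the two cores differ.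

The compounds shown carry only chloro or hydrogen at this place, so it remains open what an amine, a methoxy group or a longer chain there would do on either core. Going by these compounds, it is also open whether a gap of this kind between the two cores would appear again with those groups.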